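Swapping a Sulfamoylphenyl Amide for a Phenylbutyl Chain

The compounds below may be only part of what the source reports. "The series", "measured", "known", "first", "only" and "open" are said of these compounds alone.

Of the compounds shown here, two sharing one core have been measured in an assay on isolated protein for inhibition of NEDD8-activating enzyme E1 regulatory subunit (Homo sapiens), read by Western blot, with stated times of 10 min and 30 min, tested at 25 uM; a lower number here means less inhibition, a higher number more inhibition at the concentration tested (going by the name of the read-out). Compound 1 `CCOc1nc2cccc(C(=O)N[C@H]3CC[C@H](C(=O)OC)CC3)c2n1Cc1ccc(-c2ccccc2-c2nnn[nH]2)cc1` gives 28.6%. Going by the values given here, compound 2 `CCOc1nc2cccc(C(=O)Nc3ccc(S(N)(=O)=O)cc3)c2n1Cc1ccc(-c2ccccc2-c2nnn[nH]2)cc1` gives 60.9%, the higher of the two numbers, and the step of a number 32.3 percentage points higher from compound 1 to compound 2 (beyond the scatter) is the only comparison in hand. Compound 3 `CCOc1nc2cccc(C(=O)NCCCCc3ccccc3)c2n1Cc1ccc(-c2ccccc2-c2nnn[nH]2)cc1` is not yet measured. It differs from compound 2 in one place: 4-phenylbutyl in place of 4-sulfamoylphenyl on an amide-type nitrogen. Among the compounds with values here, the single measured step bears on this change only indirectly, since it compares the 4-sulfamoylphenyl with a 4-(methoxycarbonyl)cyclohexyl rather than with 4-phenylbutyl. A fall is nonetheless expected for compound 3 because the step of a number 32.3 percentage points higher from compound 1 to compound 2 (beyond the scatter) showed the 4-sulfamoylphenyl going with a large rise, and compound 3 gives that very group up for 4-phenylbutyl. Compound 3 is therefore expected to give 30%, within the range 10% to 55%. That expectation amounts to a step of a number 30.9 percentage points lower from compound 2 to compound 3 (beyond the scatter).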

Compound 3, a percentage reported as inhibition, at one concentration (the size of the read-out at that concentration, not a potency): 64.6%
The estimate for compound 3 lay 34.6 percentage points below the measured number, and the stated range ends below it.
By their numbers in this assay, from the lowest: compound 1; then compounds 2 and 3 (each within the scatter of the next).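

In this assay, placing 4-phenylbutyl on the amide-type nitrogen instead of 4-sulfamoylphenyl gives a number 3.7 percentage points higher from compound 2 to compound 3 (within the scatter) even though the entering group has no hydrogen-bond donors or acceptors, so those counts do not separate the two groups here. Set against the 4-(methoxycarbonyl)cyclohexyl, the same chain gives a number 36 percentage points higher from compound 1 to compound 3 (beyond the scatter) and thus shows that the large rise seen earlier is not confined to the 4-sulfamoylphenyl. No measurement at hand accounts for these two different groups reading alike.

Still open, going by these compounds, is how the reading would respond to a shorter phenylalkyl chain, a longer one, or a chain ending in an amine or a carboxylic acid. With one concentration per compound, the numbers also leave open whether compound 2 and compound 3 would stay within the scatter of each other at other concentrations.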